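From compound 2 to compound 3: one end group changes

The compounds below may be only part of what the source reports. "The series", "measured", "known", "first", "only" and "open" are said of these compounds alone.

Compound 1 `COc1cc(NC(C)CCCNC(=O)Nc2cccc(F)c2)c2ncccc2c1` gives 22000 nM
Compound 2 `COc1cc(NC(C)CCCNC(=O)NNC(=O)Nc2ccc(C(F)(F)F)cc2)c2ncccc2c1` gives 19000 nM

In a functional assay on MIA PaCa-2 cells (Homo sapiens) for inhibition, read by MTT assay, with a stated time of 72 h (on this read-out higher numbers stand for weaker inhibition and lower numbers for stronger inhibition), compound 2 gives 19000 nM, within the usual scatter of compound 1 at 22000 nM, so neither stands apart. Compound 3 `COc1cc(NC(C)CCCNC(=O)NNC(=O)Nc2cccc(F)c2)c2ncccc2c1` has 3-fluorophenyl in place of 4-(trifluoromethyl)phenyl on an amide-type nitrogen. Compound 1 also carries 3-fluorophenyl and gives 22000 nM, so no large shift is expected, in either direction. The expected change in this assay is a 1.1-fold higher number from compound 2 to compound 3 (0.02 log units; within the scatter), estimated to stay within the scatter. For compound 3 the estimated value is 20000 nM, with an expected range from 9000 nM to 45000 nM.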

Compound 3, half-maximal inhibitory concentration: 69000 nM
The estimate for compound 3 lay 3.5-fold (0.54 log units) below the measured number, outside the stated range (above it).
By their numbers in this assay, from the lowest: compounds 2 and 1 (each within the scatter of the next); then compound 3.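

In this assay, the group on this amide-type nitrogen does matter: 3-fluorophenyl in place of 4-(trifluoromethyl)phenyl gives a 3.6-fold higher number from compound 2 to compound 3 (0.56 log units; beyond the scatter). With 3-fluorophenyl kept, ((3-fluorophenyl)carbamoyl)amino in place of 3-fluorophenyl gives a 3.1-fold higher number from compound 1 to compound 3 (0.50 log units; beyond the scatter), so the step depends on what carries the ring as well as on the ring itself. No measurement here explains either step. From the compounds shown here alone, it remains open how 4-fluorophenyl or 3-(trifluoromethyl)phenyl would read at this nitrogen, which would separate the choice of fluorine or trifluoromethyl from where it sits.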